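Lengthening the Amide Side Chain Toward a Hexyl Group

The compounds below may be only part of what the source reports. "The series", "measured", "known", "first", "only" and "open" are said of these compounds alone.

Among the compounds with values here, compound 1 `COc1cc2c(cc1OC)C(CC(=O)N(C)C)CC2` gives 35.9% in a functional assay on the whole organism (strain Wistar) for inhibition, with Rattus norvegicus as the target, read by paw edema, with stated times of 60 min and 4 h, at a dose of 100 mg/kg by the oral route (a lower number here means less inhibition, a higher number more inhibition at the dose given (going by the name of the read-out)), the largest of the three numbers measured so far, though the other two lie within the usual scatter of it. Compound 2 `CCNC(=O)CC1CCc2cc(OC)c(OC)cc21` gives 26.6% and compound 3 `COc1cc2c(cc1OC)C(CC(=O)NC(C)(C)C)CC2` gives 32.8%. Compound 4 `CCCCCCNC(=O)CC1CCc2cc(OC)c(OC)cc21` has not been measured; it differs from compound 1 by hexylamino in place of dimethylamino on a carbonyl carbon. Within the data shown here, two measured steps bear on this, a number 9.3 percentage points lower from compound 1 to compound 2 (within the scatter) and a number 3.1 percentage points lower from compound 1 to compound 3 (within the scatter), both exchanging the same dimethylamino on the carbonyl carbon for another amino group, and neither moved beyond the scatter. A small downward drift at most is therefore expected, the estimated step being a number 5.9 percentage points lower from compound 1 to compound 4 (within the scatter). Compound 4 is expected to give 30%, between 15% and 45%.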

Compound 4, a percentage reported as inhibition, in the whole organism at one dose (the size of the read-out at that dose, not a potency): 42.1%
Compound 4: middle estimate off by 12.1 percentage points, on the low side, within the range that was stated.
By their numbers in this assay, from the lowest: compounds 2, 3, 1 and 4 (each within the scatter of the next, the first and the last beyond it).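

In this assay, within the data shown here, the amide nitrogen now shows a change that clears the scatter: extending the ethyl chain to hexyl gives a number 15.5 percentage points higher from compound 2 to compound 4 (beyond the scatter) and is the only step so far to do so. Both a number 6.2 percentage points higher from compound 1 to compound 4 (within the scatter) and a number 9.3 percentage points higher from compound 3 to compound 4 (within the scatter) stay within the scatter, so hexylamino cannot be set apart from dimethylamino or (tert-butyl)amino. Nothing at hand explains the effect of the longer chain. As far as these compounds go, whether an octyl chain would go further remains open, as does whether a hexyl chain ending in a carboxylic acid or an amine would keep the number.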